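The compounds below may be only part of what the source reports. "The series", "measured", "known", "first", "only" and "open" are said of these compounds alone.

Working notes on the series.

Two compounds have numbers in a functional assay on CHO cells for antagonist activity at growth hormone secretagogue receptor type 1 (Homo sapiens); on this read-out higher numbers stand for weaker inhibition and lower numbers for stronger inhibition. Compound 1 `COc1ccc(Cn2c(CCc3c[nH]c4ccccc34)nnc2[C@H](NC(=O)c2ccccn2)c2c[nH]c3ccccc23)c(OC)c1` gives 19 nM in this assay. Among the compounds with values here, compound 2 `COc1ccc(-n2c(CCc3ccccc3)nnc2[C@H](NC(=O)c2ccccn2)c2c[nH]c3ccccc23)c(OC)c1` gives 65 nM in this assay, the highest of the two numbers; the gap between the two values is beyond the usual scatter, but the two structures differ in more than one place, so no single step between them can be read off.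

Compound 3 `COc1ccc(Cn2c(CCc3ccccc3)nnc2[C@H](NC(=O)c2ccccn2)c2c[nH]c3ccccc23)cc1` is the next compound to be measured in this assay. It differs from compound 2 in one place: 4-methoxybenzyl in place of 2,4-dimethoxyphenyl on an aromatic nitrogen.

Compound 1 carries a benzyl-type link at the same ring nitrogen and gives the lower number, yet its other differences from compound 2 prevent any clean attribution, so the expectation rests on a loose reading. The step from compound 2 to compound 3 is expected to be a 1.9-fold lower number from compound 2 to compound 3 (0.27 log units; within the scatter), a modest move toward a lower number that may not clear the scatter. For compound 3 the estimate in this assay is 35 nM, with a range from 12 nM to 100 nM.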

Compound 3, antagonist equilibrium constant: 12 nM
For compound 3 the middle estimate is 2.9-fold (0.46 log units) above the measured one, within the range that was stated.
By their numbers in this assay, from the lowest: compounds 3 and 1 (each within the scatter of the next); then compound 2.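

In this assay, within the data shown here, the change on the aromatic nitrogen from 2,4-dimethoxyphenyl to 4-methoxybenzyl gives a 5.4-fold lower number from compound 2 to compound 3 (0.73 log units; beyond the scatter), the first step at this position that can be read on its own, with the phenethyl group and the rest of the structure held constant. This shows that the number responds to the group on this nitrogen, but the swap is a double change: a benzyl attachment replaces a directly attached phenyl ring, and one of the methoxy groups of 2,4-dimethoxyphenyl is gone. No measurement at hand bears on why the number moves.

The compounds shown do not separate the two parts of the change, since a 4-methoxyphenyl group on this nitrogen would isolate the benzyl attachment and compound 1, which differs from compound 3 in more than one place, gives no readable step. As far as these compounds go, how far the position tolerates other groups also stays open, for instance a longer chain such as 4-methoxyphenethyl, or a benzyl ring bearing an amine or a carboxylic acid in place of the methoxy group.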